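Working notes: from compound 3 to compound 4

This account rests on a few compounds, and the source may have more. Where it says the series, first, only, none or still open, it means among the compounds named here.

Measured in an ADME assay on HepG2 cells (Homo sapiens) for cytotoxicity; a lower number here means that less compound is tolerated, a higher number that more compound is tolerated:
- compound 1 `CSc1cccc(N(CC(=O)NC2CCCC2)C(=O)c2cc3ccc(C(F)(F)F)cc3n2C)c1`: 6300 nM
- compound 2 `CSc1cccc(N2C(=O)CN(c3cncc(C(F)(F)F)c3)CC2C(=O)NC2CCCC2)c1`: > 50000 nM (a limit)
- compound 3 `O=C(NCC1CC1)C1CN(c2ccccc2)CC(=O)N1c1ccc2ccsc2c1`: > 50000 nM (a limit)

Compound 3 gives > 50000 nM, which is a limit of this assay and not a number. Compound 2 shares the core of compound 3. Compound 2 gives > 50000 nM, also a limit. Together these two compounds account for (the limit of > 50000 nM in this assay, at which 2 of the 3 values shown sit). Compound 1 does not share that core, and it alone has a number, at 6300 nM.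

Compound 4 `NC(=O)c1cccc(NC(=O)C2CN(c3ccccc3)CC(=O)N2c2ccc3ccsc3c2)c1` keeps the core of compound 3 and carries 3-carbamoylphenyl in place of cyclopropylmethyl on an amide-type nitrogen. Among the measured compounds shown here, no measured pair shows this change or any other single change, so the expectation is only loosely grounded. Compound 2 at > 50000 nM, a limit, gives some support to expecting compound 4 to stay high on this scale. The estimated change is an at least 1.2-fold lower number from compound 3 to compound 4 (0.09 log units; that floor lies within the scatter), meaning a modest fall at most, quite possibly none beyond the scatter. A report of only a limit is the more likely outcome. For compound 4 the expected value is 40000 nM, with an estimated range of 15000 nM to 50000 nM.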

Compound 4, half-maximal cytotoxic concentration: > 50000 nM
Compound 4: only a limit was reported; the forecaster's own chance of this, stated with the estimate: 65%; middle value at least 1.2-fold (0.09 log units) from the limit.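

In this assay compound 4 gives > 50000 nM, which is a limit of the assay and not a number. Compound 3 also stands at a limit, so no step can be read between compound 3 and compound 4. The compounds shown leave open whether 3-carbamoylphenyl in place of cyclopropylmethyl on an amide-type nitrogen changes this read-out at all.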